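Compound 3 to compound 4: thiophen-2-yl for furan-2-yl

A few compounds are considered here, and "the series" means these few. Any claim that something is new, unique, unknown or untested is made for them only; others in the source may bear on it.

In a toxicity assay on MT4 cells (Homo sapiens) for cytotoxicity, read by MTT assay, with a stated time of 5 days (on this read-out higher numbers stand for lower toxicity in this test and lower numbers for higher toxicity in this test), compound 3 `Cc1cc(-c2ccco2)cc(C)c1Nc1ccnc(Nc2ccc(C#N)cc2)n1` gives 1700 nM. Compound 1 `Cc1cnc(Nc2ccc(C#N)cc2)nc1Nc1c(F)cc(-c2cncnc2)cc1F` gives 900 nM, within the usual scatter of compound 3, so these two cannot be ranked. Compound 2 `Cc1cnc(Nc2ccc(C#N)cc2)nc1Nc1c(F)cc(-c2ccsc2)cc1F` gives 261000 nM, the highest number of the three and beyond the scatter from both others.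

The next compound, compound 4 `Cc1cc(-c2cccs2)cc(C)c1Nc1ccnc(Nc2ccc(C#N)cc2)n1`, carries a single change: thiophen-2-yl in place of furan-2-yl on an aromatic carbon. The exchange sits on an aromatic carbon of a six-membered aromatic ring of carbon only, and both groups are five-membered aromatic rings with 1 hetero atom.

Going by the values given here, no measured step makes this exchange. The closest evidence is a 290-fold higher number from compound 1 to compound 2 (2.46 log units; beyond the scatter), a large step with thiophen-3-yl in place of pyrimidin-5-yl. It starts from a different group on another core, so it gives a direction at most and not a size. A step upward in this assay is therefore expected, much smaller than that one, and a result within the scatter would be no surprise.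

The estimated change is a 2.9-fold higher number from compound 3 to compound 4 (0.47 log units; beyond the scatter). For compound 4 the expected value is 5000 nM, with an estimated range of 1300 nM to 40000 nM.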

Compound 4, half-maximal cytotoxic concentration: 10000 nM
Compound 4: middle estimate off by 2.0-fold (0.30 log units), on the low side, and the stated range covers the measured number.
By their numbers in this assay, from the lowest: compounds 1 and 3 (each within the scatter of the next); then compound 4; then compound 2.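

The exchange on the core of compound 3, on an aromatic carbon meta to two methyl groups, gives in this assay a 5.9-fold higher number from compound 3 to compound 4 (0.77 log units; beyond the scatter), so this position responds to a change of hetero atom alone. Heavy atom count, ring size, hydrogen-bond donor and acceptor counts and net charge all stay the same across this step, so none of these counts separates furan-2-yl from thiophen-2-yl, whereas a 290-fold higher number from compound 1 to compound 2 (2.46 log units; beyond the scatter) on the core of compound 1 also changes ring size and hetero atom count. Both steps run upward on entry of a thiophene ring, but they share neither core nor leaving group, and no measurement at hand explains the step in either size or direction.

On these data alone, whether the sulfur-for-oxygen exchange gives a step of similar size on the core of compound 1 remains open, as does the comparison of thiophen-2-yl with thiophen-3-yl on a single core. Also open, as far as these compounds go, is how a phenyl ring, a morpholine or a carboxylic acid would read at this position on the core of compound 3.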